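Chloro added to a dinitro diaryl ether oxime series

This account rests on a few compounds, and the source may have more. Where it says the series, first, only, none or still open, it means among the compounds named here.

Compound 1 `O=[N+]([O-])c1cc(C(F)(F)F)cc([N+](=O)[O-])c1Oc1ccccc1/C=N\OCc1ccccc1F` gives 680 nM in a functional assay on HepG2 cells (Homo sapiens) for antiproliferative activity, read by MTT assay, with a stated time of 48 h; a lower number here means a stronger inhibitor, a higher number a weaker inhibitor. Compound 2 `O=[N+]([O-])c1cc(C(F)(F)F)cc([N+](=O)[O-])c1Oc1ccc(Cl)cc1/C=N\OCc1ccccc1` gives 1790 nM in this assay. Compound 3 `O=[N+]([O-])c1cc(C(F)(F)F)cc([N+](=O)[O-])c1Oc1ccc(Cl)cc1/C=N\OCc1ccccc1F` gives 1020 nM in this assay.

Compound 3 arises from compound 1 by chloro in place of hydrogen on an aromatic carbon, and this brought a 1.5-fold higher number from compound 1 to compound 3 (0.18 log units; within the scatter). Compound 3 also relates to compound 2 through a fluoro in place of hydrogen, with a 1.8-fold lower number from compound 2 to compound 3 (0.24 log units; within the scatter). The difference between the cores of compound 1 and compound 2 is not broken down here.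

The unmeasured compound 4 `O=[N+]([O-])c1cc(C(F)(F)F)cc([N+](=O)[O-])c1Oc1c(Cl)cc(Cl)cc1/C=N\OCc1ccccc1` arises from compound 2 by chloro in place of hydrogen on an aromatic carbon. For the measured compounds named here, this is the same kind of change as the one from compound 1 to compound 3, but at a different place: here the new chloro sits ortho to a large group and meta to a chloro group, whereas before it sat meta and para to a large group. Since the earlier step stayed within the scatter, a similar small step is expected, a 1.3-fold higher number from compound 2 to compound 4 (0.11 log units; within the scatter), resting on compound 1 and compound 3 with a 1.5-fold higher number from compound 1 to compound 3 (0.18 log units; within the scatter). Compound 4 is therefore estimated at 2300 nM, between 1100 nM and 5000 nM.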

Compound 4, half-maximal inhibitory concentration: 1120 nM
Compound 4: middle estimate off by 2.1-fold (0.31 log units), on the high side; the range from low to high includes it.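

In this assay, the step for this chloro reads a 1.6-fold lower number from compound 2 to compound 4 (0.20 log units; within the scatter), so on the core of compound 2 the added chloro leaves the number within the usual scatter. Set beside the earlier chloro step, the two results point opposite ways on paper, yet the gap between them is no more than repeated measurements could produce: the same change on two cores in this assay, a 1.5-fold higher number (0.18 log units; within the scatter) from compound 1 to compound 3 and a 1.6-fold lower number (0.20 log units; within the scatter) from compound 2 to compound 4, 2.4-fold (0.38 log units) apart, within the scatter of two such steps. For the compounds shown here, this shows that, in these two cases, the change stays small on both cores, but it rests on only two pairs with the chloro at different places, so it does not establish a general rule for the series or a true difference between the cores.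

The compounds shown carry only hydrogen or chloro at these places, so it remains open how a methoxy group, an amine or a carboxylic acid would behave there. Also open, as far as these compounds go, is what a fluoro would do on compound 4, where it would sit alongside both chloro groups.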